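The compounds below may be only part of what the source reports. "The series", "measured", "known", "first", "only" and "open" are said of these compounds alone.

Measured compounds:
compound 1 `COc1ccc(N2C[C@@H](C)N[C@@H](C)C2)cc1NS(=O)(=O)c1ccc(-c2cnco2)s1`, 0.9
compound 2 `COc1ccc(N2C[C@@H](C)N[C@@H](C)C2)cc1NS(=O)(=O)c1ccc(-c2ccc(C)o2)cc1`, 1
compound 3 `COc1ccc(N2C[C@@H](C)N[C@@H](C)C2)cc1NS(=O)(=O)c1cccc(-c2ccco2)c1`, 1

In a functional assay for agonist activity at growth hormone secretagogue receptor type 1 (Homo sapiens), read by FLIPR (on this read-out higher numbers stand for larger maximal responses and lower numbers for smaller maximal responses), compound 3 gives 1, level with compound 2 at the digits shown, the two together the highest of the three numbers; compound 1 gives 0.9, a shade lower but within the scatter of repeated measurements, so no order among the three can be claimed.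

Compound 4 `COc1ccc(N2C[C@@H](C)N[C@@H](C)C2)cc1NS(=O)(=O)c1cccc(-c2ccccc2)c1` is not yet measured. It differs from compound 3 in one place: phenyl in place of furan-2-yl on an aromatic carbon. Among the compounds with values here, no measured pair carries this change, so nothing anchors it directly. Since compound 2 gives 1 and compound 3 gives 1 with differing groups at this position, the expected movement from compound 3 to compound 4 is a number 0.050 lower from compound 3 to compound 4 (within the scatter), nothing beyond the scatter. Compound 4 is estimated at 0.95, with a range from 0.8 to 1.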

Compound 4, intrinsic activity: the largest response reached, as a fraction of the reference agonist's: 1
Beside the measured number, compound 4's estimate is 0.050 below it; the range from low to high includes it.
By their numbers in this assay, from the lowest: compounds 1, 2, 3 and 4 (each within the scatter of the next).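

In this assay, phenyl in place of furan-2-yl on an aromatic carbon, meta to a large group, gives no change at the digits printed from compound 3 to compound 4 (within the scatter). Within the data shown here, this is the first one-place comparison, and it shows that the maximal response at this position holds with a six-membered carbocycle carrying no hydrogen-bond acceptor as well as with the five-membered furan-2-yl ring.

From the compounds shown here alone, whether a non-aromatic group here, such as an amine, a carboxylic acid or a longer alkyl chain, keeps that response stays open. So does any difference in potency, which a maximal response cannot show. No available evidence explains why the two rings read alike.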